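The source may hold more compounds than are shown below. What is called first, only, known or untested is meant among the compounds shown, and "the series" means these compounds.

Measured in an assay on membranes from CHO cells for displacement of a labelled ligand from adenosine receptor A1 (Homo sapiens), read by scintillation counting, with a stated time of 60 min, tested at 1 uM; on this read-out lower numbers stand for less inhibition and higher numbers for more inhibition at the one concentration tested (going by the name of the read-out):

Compound 1, `CC1=C(C(=O)OCc2ccccc2)C(c2ccsc2)NC(=O)N1`: compound 1 gives 57%.
Compound 2, `CC1=C(C(=O)SC(C)C)C(c2ccsc2)NC(=O)N1`: compound 2 gives 24%.
Compound 3, `CCC(C)OC(=O)C1=C(C)NC(=O)NC1c1cccs1`: compound 3 gives 5%.

Compound 3 has the lowest number of the three in this assay. Its nearest neighbour is compound 2, whose number lies beyond the usual scatter above it, and compound 1 lies further still above it, also beyond the scatter. Compound 3 therefore stands apart at the bottom of this small set.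

Compound 4, `CCC(C)OC(=O)C1=C(C)NC(=O)NC1c1ccsc1`, differs from compound 3 in one place: thiophen-3-yl in place of thiophen-2-yl on a saturated ring carbon. For the measured compounds named here, no pair of measured compounds differs in this one place alone, so the size of this step is not known from a measurement. Compounds 1 and 2, which both carry thiophen-3-yl, show higher numbers than compound 3, but they also carry different groups elsewhere, so their values only hint at the direction.

The expected step in this assay from compound 3 to compound 4 is a number 15 percentage points higher from compound 3 to compound 4 (beyond the scatter), a modest rise. Compound 4 is therefore estimated at 20%, with a range from 2% to 45%.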

Compound 4, a percentage reported as inhibition, at one concentration (the size of the read-out at that concentration, not a potency): 5%
The estimate for compound 4 lay 15 percentage points above the measured number; low and high end bracket the measured number.
By their numbers in this assay, from the lowest: compounds 3 and 4 (each within the scatter of the next); then compound 2; then compound 1.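

In this assay, thiophen-3-yl in place of thiophen-2-yl on the saturated ring carbon gives no change at the digits printed from compound 3 to compound 4 (within the scatter) and so, with sec-butoxy on the carbonyl carbon, the two thiophene attachments read alike. The group on the carbonyl carbon is where the number moves among these compounds: sec-butoxy in place of isopropylsulfanyl gives a number 19 percentage points lower from compound 2 to compound 4 (beyond the scatter) and sec-butyl in place of benzyl on the oxygen gives a number 52 percentage points lower from compound 1 to compound 4 (beyond the scatter) while the thiophen-3-yl stays the same in all three.

Going by these compounds, whether the two thiophene attachments would still read alike with a benzyl group on the oxygen stays open. So does the effect of a phenyl or furan-2-yl ring on the same saturated ring carbon, or of a longer chain on the oxygen. No measurement at hand accounts for these steps.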